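The source may hold more compounds than are shown below. What is called first, only, known or untested is meant among the compounds shown, and "the series" means these compounds.

Of the compounds shown here, two have been measured here. Compound 1 `Nc1ncnc2c1nc(-c1ccccc1)n2[C@H]1C[C@H](O)[C@@H](COP(=O)(O)OP(=O)(O)OC[C@H]2OC(O)[C@H](O)[C@@H]2O)O1` is a nucleotide-like molecule whose base carries a phenyl group; in an assay on HEK293 cells for antagonist activity at transient receptor potential cation channel subfamily M member 2 (Homo sapiens), read by patch clamp (on this read-out lower numbers stand for stronger inhibition and higher numbers for weaker inhibition), compound 1 gives 3000 nM. Compound 2 `Nc1ncnc2c1cc(Br)n2[C@@H]1O[C@H](COP(=O)(O)OP(=O)(O)OC[C@H]2OC(O)[C@H](O)[C@@H]2O)[C@@H](O)[C@H]1O` carries a base that holds a bromine atom; in this assay compound 2 is recorded as "not active" (no number reported), so no number stands behind it and it cannot be placed on the scale of compound 1. Compound 3 `Nc1ncnc2c1nc(N)n2[C@@H]1O[C@H](COP(=O)(O)OP(=O)(O)OC[C@H]2OC(O)[C@H](O)[C@@H]2O)[C@@H](O)[C@H]1O` has not yet been measured. It differs from compound 2 in one place: a group of 11 heavy atoms (5 carbon, 6 nitrogen; one five-membered aromatic ring with 2 hetero atoms, one six-membered aromatic ring with 2 hetero atoms) in place of a group of 11 heavy atoms (6 carbon, 4 nitrogen, 1 bromine; one five-membered aromatic ring with 1 hetero atom, one six-membered aromatic ring with 2 hetero atoms), on a saturated ring carbon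

The two heavy-atom groups are of the same size, but the group that enters has more nitrogen atoms and more hydrogen-bond donors and acceptors. For the measured compounds named here, since compound 2 gave no number, no step can be computed, and the only anchor is compound 1 with its weak inhibition. Going from compound 2 to compound 3, some gain is expected, from no measurable activity to a weak but measurable one, yet a result that again lands outside the measurable range is quite possible. Compound 3 is expected to give about 40000 nM, with a likely range from 8000 nM to 200000 nM.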

Compound 3, half-maximal inhibitory concentration: "not active" (no number reported)
For compound 3 the study gives words and no number, and the estimate cannot be compared.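

Compound 2 and compound 3 are both recorded as not active with no number, so no step between them can be read, and no further data shown here bear on this result. The compounds shown leave open whether either base differs at all from the other in inhibition, and how either compares with compound 1.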